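From furan-3-yl to thiophen-2-yl: a small expected step

The source may hold more compounds than are shown below. What is called first, only, known or untested is meant among the compounds shown, and "the series" means these compounds.

In a functional assay on A-375 cells (Homo sapiens) for activation, with a stated time of 3 days (a lower number here means that less compound is needed, a higher number that more compound is needed for the effect), compound 1 `O=C(Nc1ccc(-c2ccncc2)cc1)C1CCCN(Cc2ccc(F)c(F)c2)C1` gives 1180 nM and compound 2 `O=C(Nc1ccc(-c2ccn[nH]2)cc1)C1CCCN(Cc2ccc(F)c(F)c2)C1` gives 580 nM while compound 3 `O=C(Nc1ccc(-c2ccoc2)cc1)C1CCCN(Cc2ccc(F)c(F)c2)C1` gives 3000 nM as the highest number of the three. Compound 4 `O=C(Nc1ccc(-c2cccs2)cc1)C1CCCN(Cc2ccc(F)c(F)c2)C1` has thiophen-2-yl in place of furan-3-yl on an aromatic carbon and keeps the rest of the shared core. Both groups are a five-membered aromatic ring with 1 hetero atom.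

Three measured steps change this same group: a 2.0-fold lower number from compound 1 to compound 2 (0.31 log units; beyond the scatter) and a 2.5-fold higher number from compound 1 to compound 3 (0.41 log units; beyond the scatter) and a 5.2-fold higher number from compound 2 to compound 3 (0.71 log units; beyond the scatter) are all modest. Among the measured compounds shown here, each of them exchanges rings of different kinds, and no measured step swaps two rings of the same kind. A smaller step is therefore expected in this assay with perhaps a slight drop in the number, and it may well stay within the scatter. The expected change is a 1.3-fold lower number from compound 3 to compound 4 (0.10 log units; within the scatter) on this estimate. For compound 4 the estimated value is 2400 nM with an expected range from 1000 nM to 5500 nM for now.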

Compound 4, half-maximal effective concentration: 530 nM
Compound 4: middle estimate off by 4.5-fold (0.66 log units), on the high side; measured number outside the range, below it.
By their numbers in this assay, from the lowest: compounds 4 and 2 (each within the scatter of the next); then compound 1; then compound 3.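

In this assay, among the compounds shown here, this position separates two rings that match in kind and in counted features: a 5.7-fold lower number from compound 3 to compound 4 (0.75 log units; beyond the scatter) is no smaller than the steps between rings of different kinds. Furan-3-yl and thiophen-2-yl have the same heavy-atom, donor and acceptor counts and no net charge, so these counts alone do not predict the result here. Thiophen-2-yl also gives a 1.1-fold lower number from compound 2 to compound 4 (0.04 log units; within the scatter) and, against the six-membered ring, a 2.2-fold lower number from compound 1 to compound 4 (0.35 log units; beyond the scatter) as the last step.

Nothing available explains the size of the step from furan-3-yl to thiophen-2-yl. Sulfur replaces oxygen and the ring's attachment point also changes, so furan-2-yl and thiophen-3-yl would be needed to tell apart these two differences.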